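The source may hold more compounds than are shown below. What is called first, only, known or untested is meant among the compounds shown, and "the series" means these compounds.

Compound 1 `COc1cc(Cl)cc(-c2nn(-c3cccc(NC(=O)Nc4ccc(Cl)c(Cl)c4)c3)cc2-c2ccncc2)c1` — in a functional assay on SK-MEL-5 cells (Homo sapiens) for inhibition, read by sulforhodamine B assay, with a stated time of 48 h, tested at 0.01 uM (on this read-out lower numbers stand for a stronger effect and higher numbers for a weaker effect at the one concentration tested), compound 1 gives 95%.
Compound 2 `COc1cc(Cl)cc(-c2nn(-c3cccc(NC(=O)Nc4cccc(C(F)(F)F)c4)c3)cc2-c2ccncc2)c1` — in this assay compound 2 gives 96%.

The two measured compounds share one core and differ only in the aryl group carried on the amide-type nitrogen of the urea. Going by the values given here, the single measured step, a number 1 percentage points higher from compound 1 to compound 2 (within the scatter), lies within the scatter, so compound 2 stands side by side with compound 1 on this read-out; both numbers sit close to the top of the scale, which at this concentration means little inhibition for either compound.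

Compound 3 `COc1cc(Cl)cc(-c2nn(-c3cccc(NC(=O)c4cccc(C(F)(F)F)c4)c3)cc2-c2ccncc2)c1` has not yet been measured. It differs from compound 2 by 3-(trifluoromethyl)phenyl in place of (3-(trifluoromethyl)phenyl)amino on a carbonyl carbon. Among the compounds with values here, no measured step touches the carbonyl carbon: the step from compound 1 to compound 2 exchanges only the aryl group on the nitrogen and stayed within the scatter, so it offers no direct guide for this change. With both measured values already near the top of the scale, there is little room for a rise, and nothing in the data points to a fall beyond the scatter. Compound 3 is therefore expected to give 95%, with a range from 84% to 104%, and the expected step of a number 1 percentage points lower from compound 2 to compound 3 (within the scatter) is expected to remain within the scatter.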

Compound 3, a percentage reported as activity, at one concentration (the size of the read-out at that concentration, not a potency): 97%
Beside the measured number, compound 3's estimate is 2 percentage points below it, and the stated range covers the measured number.
By their numbers in this assay, from the lowest: compounds 1, 2 and 3 (each within the scatter of the next).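

In this assay, the exchange of (3-(trifluoromethyl)phenyl)amino for 3-(trifluoromethyl)phenyl on the carbonyl carbon turns the urea of compound 2 into an amide, and it gives a number 1 percentage points higher from compound 2 to compound 3 (within the scatter) at this position. The earlier step had altered only the aryl group on the nitrogen, whereas this change takes away the nitrogen itself together with its hydrogen-bond donor, and the read-out at this one concentration still shows no difference beyond the scatter. The same holds for the exchange starting from the dichlorinated urea, which gives a number 2 percentage points higher from compound 1 to compound 3 (within the scatter) and so adds a second comparison at the carbonyl carbon, though no measurement at hand bears on why these compounds read alike.

The three compounds leave open whether any group on the carbonyl carbon can move the number beyond the scatter in this assay at this concentration, given that all three values lie together near the top of the scale. From the compounds shown here alone, it also stays open how a methylene in place of the carbonyl, or an amine or a carboxylic acid in place of the trifluoromethyl group, would read here.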